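This account rests on a few compounds, and the source may have more. Where it says the series, first, only, none or still open, it means among the compounds named here.

Three related compounds have so far been tested in a functional assay on SMMC-7721 cells (Homo sapiens) for antiproliferative activity, read by MTT assay, with a stated time of 48 h; a higher number here means a weaker inhibitor, a lower number a stronger inhibitor. Compound 1 `CC(=O)OC/C1=C/C[C@](C)(CCC=C(C)C)/C=C/[C@@H](OC(=O)C=C(C)C)[C@](C)(OC(C)=O)/C=C/C1=O` gives 4130 nM in this assay. Compound 2 `C=C1/C=C/C(=O)/C(CO)=C\C[C@](C)(CCC=C(C)C)/C=C/[C@H]1OC(=O)C=C(C)C` gives 4300 nM in this assay. Compound 3 `CC(C)=CCC[C@]1(C)/C=C/[C@@H](OC(=O)C=C(C)C)[C@](C)(O)/C=C/C(=O)/C(C(=O)O)=C\C1` is recorded in this assay only as > 10000 nM, which is a limit of the assay rather than a number, so its true value is not known; this is the limit of > 10000 nM in this assay, at which 1 of the 3 values shown sits.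

Compound 4 `COCOC/C1=C/C[C@](C)(CCC=C(C)C)/C=C/[C@@H](OC(=O)C=C(C)C)[C@](C)(O)/C=C/C1=O` has not yet been measured in this assay. It differs from compound 3 in a single place: (methoxymethoxy)methyl in place of carboxy on a double-bonded ring carbon. Among the measured compounds shown here, because compound 3 is known only as a limit, no measured step sets the size of this change. Compound 1 and compound 2, which carry no carboxy group, both fall in the same region of this assay, and compound 4 is expected to land near them. The step from compound 3 to compound 4 is therefore expected to run toward stronger inhibition, estimated as an at least 2.0-fold lower number from compound 3 to compound 4 (0.30 log units; that floor lies within the scatter). Compound 4 is expected to give about 5000 nM in this assay, with a likely range from 2500 nM to 12000 nM.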

Compound 4, half-maximal inhibitory concentration: 3250 nM
The estimate for compound 4 lay 1.5-fold (0.19 log units) above the measured number; the measured number falls inside the stated range.
By their numbers in this assay, from the lowest: compounds 4, 1 and 2 (each within the scatter of the next). At a limit, above all of these: compound 3.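

In this assay, among the compounds shown here, putting (methoxymethoxy)methyl in place of carboxy on the double-bonded ring carbon gives an at least 3.0-fold lower number from compound 3 to compound 4 (0.48 log units; beyond the scatter), the first sign that the group at this position matters for the read-out. This size is only a minimum, since compound 3 is known solely as a limit of the assay: the limit of > 10000 nM in this assay, at which 1 of the 4 values shown sits. The true gap could be much larger, and the compounds shown cannot say by how much.

This single change removes carboxy and adds (methoxymethoxy)methyl at once, which leaves open whether the loss of the first or the arrival of the second accounts for the step. From the compounds shown here alone, how an aminomethyl group or a methyl ester would behave on the same ring carbon also remains open.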